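Swapping the sulfonyl substituent of a stable anilide

The source may report more compounds than this note shows. Statements on the series, on what has been measured and on what is new or still open speak of the compounds shown alone.

Compound 1 `CC(C)S(=O)(=O)NC(=O)c1ccc(Nc2nc(NC3(c4ccc(Cl)cc4)CC3)nc(OCC(F)(F)F)n2)cc1` was tested in an ADME assay on microsomes from liver (Rattus norvegicus) for metabolic stability, with a stated time of 10 min (on this read-out higher numbers stand for a more stable compound and lower numbers for a less stable compound), where compound 1 gives 96%. Two analogues sharing its core have been measured on the same read-out. Compound 2 `CC(C)(C)NC(=O)NCCS(=O)(=O)NC(=O)c1ccc(Nc2nc(NC3(c4ccc(Cl)cc4)CC3)nc(OCC(F)(F)F)n2)cc1` carries a 2-(((tert-butyl)carbamoyl)amino)ethyl in place of isopropyl on the sulfonyl sulfur, and in this assay compound 2 gives 93%; the step of a number 3 percentage points lower from compound 1 to compound 2 (within the scatter) is within the scatter, so compound 1 and compound 2 stand alongside each other. Within the data shown here, compound 3 `O=C(NS(=O)(=O)CCNC(=O)C1CC1)c1ccc(Nc2nc(NC3(c4ccc(Cl)cc4)CC3)nc(OCC(F)(F)F)n2)cc1` was reported in this assay only as "not active" (no number reported), without a number, and no step to it can be stated.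

Compound 4 `O=C(NS(=O)(=O)c1ccccc1)c1ccc(Nc2nc(NC3(c4ccc(Cl)cc4)CC3)nc(OCC(F)(F)F)n2)cc1` has not yet been measured. It differs from compound 1 by phenyl in place of isopropyl on a sulfonyl sulfur. Among the measured compounds shown here, the only step that bears on this position, a number 3 percentage points lower from compound 1 to compound 2 (within the scatter), was within the scatter despite a far larger replacement of the isopropyl, which suggests that the sulfonyl substituent can be exchanged without a large loss on this read-out. Compound 4 is therefore expected to remain close to compound 1, with a step of a number 5 percentage points lower from compound 1 to compound 4 (within the scatter) that is estimated to stay within the scatter. The estimate for compound 4 in this assay is 91%, with a range from 76% to 99%.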

Compound 4, percent of the compound remaining: 100%
For compound 4 the middle estimate is 9 percentage points below the measured one; measured number above the stated range.
By their numbers in this assay, from the lowest: compounds 2, 1 and 4 (each within the scatter of the next).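

With phenyl on the sulfonyl sulfur, the position now carries a six-membered aromatic ring of carbon only, and a number 4 percentage points higher from compound 1 to compound 4 (within the scatter) in this assay shows that this exchange for isopropyl leaves the reading unchanged within the scatter, while a number 7 percentage points higher from compound 2 to compound 4 (within the scatter) shows the same for the exchange of the 2-(((tert-butyl)carbamoyl)amino)ethyl chain for phenyl. Isopropyl, phenyl and that longer chain therefore stand together on this read-out, so the tolerance seen at this position now extends to an aromatic ring, but steps to compound 3 cannot be read and it stays outside this statement, with its cyclopropyl-capped chain. No measured evidence is available that would explain this tolerance.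

A phenyl ring bearing a chlorine or methoxy group, a sulfonyl substituent ending in an amine or a carboxylic acid, and a smaller group such as methyl are not among the compounds shown. From the compounds shown here alone, whether any of these would move the reading away from the group formed by compounds 1, 2 and 4 therefore remains open.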